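A few compounds are considered here, and "the series" means these few. Any claim that something is new, unique, unknown or untested is made for them only; others in the source may bear on it.

Measured so far:
- Compound 1 `CCSCCC12CCC(c3nnc(-c4ccccc4C(F)(F)F)n3C)(CC1)CC2` gives > 4000 nM in an assay on CHO-K1 cells for inhibition of 11-beta-hydroxysteroid dehydrogenase type 2 (Mus musculus), read by scintillation proximity assay (a higher number here means a weaker inhibitor, a lower number a stronger inhibitor), which is a limit of the assay rather than a number.
- Compound 2 `CC(C)S(=O)(=O)CCC12CCC(c3nnc(-c4ccccc4C(F)(F)F)n3C)(CC1)CC2` gives > 4000 nM in this assay, again only a limit.
- Compound 3 `Cn1c(-c2ccccc2C(F)(F)F)nnc1C12CCC(COc3ccc(S(C)(=O)=O)cc3)(CC1)CC2` gives > 4000 nM in this assay, also a limit.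

Compound 1 therefore stands only at the limit, as do the other two, and the steps a step that the two limits leave unreadable from compound 1 to compound 2 and a step that the two limits leave unreadable from compound 1 to compound 3 cannot be sized, since (the limit of > 4000 nM in this assay, at which 3 of the 3 values shown sit). The unmeasured compound 4 `CCCCCC12CCC(c3nnc(-c4ccccc4C(F)(F)F)n3C)(CC1)CC2` differs from compound 1 by propyl in place of ethylsulfanyl on a saturated chain carbon, two bonds along the chain from a saturated ring carbon. Going by the values given here, no measured step bears on this change in a readable size; the two known changes at the same chain position simply left the value at the limit. Compound 4 is therefore expected to sit at the limit as well, most likely. For compound 4 the estimate is 8000 nM, with a range from 3000 nM to 40000 nM. This corresponds to an expected step that the limit leaves unreadable from compound 1 to compound 4.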

Compound 4, half-maximal inhibitory concentration: > 4000 nM
Compound 4: only a limit was reported; the forecaster's own chance of this, stated with the estimate: 85%; the middle value does not contradict the limit.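

Compound 4 gives no readable step against compound 1, compound 2 or compound 3, because all four stop at the same limit: the limit of > 4000 nM in this assay, at which 4 of the 4 values shown sit. The compounds shown leave open whether any of these chain groups changes inhibition in this assay.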